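Swapping the styryl aryl of a trimethoxychalcone for 4-chlorophenyl

The compounds below may be only part of what the source reports. "The series", "measured", "known", "first", "only" and "open" are said of these compounds alone.

Compound 1 `COc1cc(OC)c(C(=O)/C=C/c2ccccc2SC)c(OC)c1` is a chalcone carrying a 2-(methylsulfanyl)phenyl group on the double-bonded chain carbon. In a functional assay on HaCaT cells (Homo sapiens), read by fluorescence and BrdU incorporation, with a stated time of 48 h, tested at 10 uM (on this read-out higher numbers stand for a weaker effect at the one concentration tested and lower numbers for a stronger effect), compound 1 gives 24%, the second highest of the three numbers measured. Its nearest neighbour is compound 2 `COc1cccc(/C=C/C(=O)c2c(OC)cc(OC)cc2OC)c1`, which in this assay gives 19%; the step of a number 5 percentage points lower from compound 1 to compound 2 (within the scatter) lies within the scatter. Compound 3 `COc1cc(O)c(C(=O)/C=C/c2ccccc2OC)c(OC)c1`, with a free hydroxyl on the core, gives in this assay 49%, a number that stands above compound 1 by more than the scatter allows.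

Compound 4 `COc1cc(OC)c(C(=O)/C=C/c2ccc(Cl)cc2)c(OC)c1` has not been measured. It differs from compound 1 in one place: 4-chlorophenyl in place of 2-(methylsulfanyl)phenyl on a double-bonded chain carbon bound to a double-bonded chain carbon. Among the compounds with values here, the only measured step that bears on this change is the aryl swap a number 5 percentage points lower from compound 1 to compound 2 (within the scatter), which was small. A step of similar size, in either direction or none beyond the scatter, is therefore expected for a number 4 percentage points higher from compound 1 to compound 4 (within the scatter). Compound 4 is estimated to give 28% in this assay, with a range from 12% to 48%.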

Compound 4, a percentage reported as activity, at one concentration (the size of the read-out at that concentration, not a potency): 26%
Compound 4: the middle estimate sits 2 percentage points above what was measured; the measured number falls inside the stated range.
By their numbers in this assay, from the lowest: compounds 2, 1 and 4 (each within the scatter of the next); then compound 3.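

In this assay, a third aryl group now joins the two already seen on the double-bonded chain carbon, and neither new comparison leaves the scatter: the first is a number 2 percentage points higher from compound 1 to compound 4 (within the scatter), and the second is a number 7 percentage points higher from compound 2 to compound 4 (within the scatter). The sulfur-bearing 2-(methylsulfanyl)phenyl, the 3-methoxyphenyl and the chlorine-bearing 4-chlorophenyl therefore cannot be told apart at this place, including when the entering group has no hydrogen-bond acceptor. Nothing available explains this lack of separation.

Going by these compounds, whether an aryl group carrying an amine or a carboxylic acid at this place would give a step beyond the scatter remains open. On these data alone, compound 3 differs from the others in more than one place, so the contribution of its free hydroxyl on the core also remains open.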